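Fluorine on Benzyl Amide in a T-type Calcium Channel Series

The source may report more compounds than this note shows. Statements on the series, on what has been measured and on what is new or still open speak of the compounds shown alone.

Compound 1 `O=C(CC1c2ccccc2N=C(SCCCCCN2CCCC2)N1c1ccc(-c2ccccc2)cc1)NCc1ccc(F)cc1` gives 51.5% in an assay on cells for inhibition of Voltage-dependent T-type calcium channel subunit alpha-1G (Homo sapiens), read by patch clamp, tested at 10 uM; a lower number here means less inhibition, a higher number more inhibition at the concentration tested (going by the name of the read-out). Compound 3 `O=C(CC1c2ccccc2N=C(SCCCCCN2CCCC2)N1c1ccc(-c2ccc(F)cc2)cc1)NCc1ccc(F)cc1` gives 83.9% in this assay, and the step of a number 32.4 percentage points higher from compound 1 to compound 3 (beyond the scatter) is fluoro in place of hydrogen on an aromatic carbon. Compound 2 `CN(C)CCCCCSC1=Nc2ccccc2C(CC(=O)NCc2ccccc2)N1c1ccc(-c2ccccc2)cc1` carries a different core; the difference between the two cores is not broken down here. In this assay compound 2 gives 76.2%, which stands within the scatter of compound 3 and beyond it above compound 1. Compound 4 `CN(C)CCCCCSC1=Nc2ccccc2C(CC(=O)NCc2ccc(F)cc2)N1c1ccc(-c2ccccc2)cc1` is not yet measured; it differs from compound 2 by fluoro in place of hydrogen on an aromatic carbon, the same change as from compound 1 to compound 3, although read one bond further out it is benzyl to 4-fluorobenzyl rather than phenyl to 4-fluorophenyl. The step of a number 7.8 percentage points higher from compound 2 to compound 4 (within the scatter) is expected to be smaller than the earlier one because a number 32.4 percentage points higher from compound 1 to compound 3 (beyond the scatter) started from a lower value and the read-out cannot rise far above the value of compound 2. Compound 4 is estimated at 84%, between 68% and 95%.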

Compound 4, a percentage reported as inhibition, at one concentration (the size of the read-out at that concentration, not a potency): 31%
For compound 4 the middle estimate is 53 percentage points above the measured one; the measured number lies below the stated range.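

Fluoro in place of hydrogen on an aromatic carbon did not carry over from one core to the other in this assay, and the two steps run in opposite directions: the same change on two cores in this assay, a number 32.4 percentage points higher (beyond the scatter) from compound 1 to compound 3 and a number 45.2 percentage points lower (beyond the scatter) from compound 2 to compound 4, 77.6 percentage points apart, beyond the scatter of two such steps. The new step, a number 45.2 percentage points lower from compound 2 to compound 4 (beyond the scatter), adds the fluoro to a benzyl group, whereas the earlier one adds it to a phenyl group, so the comparison does not separate the effect of the core from that of the ring carrying the fluoro. With the 4-fluorobenzyl group kept, dimethylamino in place of pyrrolidin-1-yl gives a number 20.5 percentage points lower from compound 1 to compound 4 (beyond the scatter).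

The compounds shown leave open how chloro or methoxy in place of the fluoro would behave on either core. They also leave open whether a piperidine at the chain end or a shorter chain would follow either step.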